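Removing the Amide Methyl from a Kinase Inhibitor Core

This account rests on a few compounds, and the source may have more. Where it says the series, first, only, none or still open, it means among the compounds named here.

In an assay for inhibition of Rho-associated protein kinase 1 (Homo sapiens), read by TR-FRET, with stated times of 5 min and 2 h (on this read-out higher numbers stand for weaker inhibition and lower numbers for stronger inhibition), compound 1 `CN1C(=O)c2sc(-c3ccncc3)cc2NC1(C)C` gives 240 nM, the lowest of the three numbers recorded so far. Compound 3 `Cc1n[nH]cc1-c1cc2c(s1)C(=O)N[C@]1(CC[C@@](O)(C3CCCCC3)CC1)N2` gives 350 nM, which lies within the usual scatter of the value of compound 1, so the two cannot be told apart. Compound 2 `Cc1n[nH]c(C)c1-c1cc2c(s1)C(=O)NC(C)(C)N2C` gives 2100 nM, a clearly higher number than compound 1 and therefore weaker inhibition. Compound 4 `CC1(C)NC(=O)c2sc(-c3ccncc3)cc2N1` has not yet been measured. It differs from compound 1 in one place: hydrogen in place of methyl on an amide-type nitrogen in a ring. Going by the values given here, no pair of measured compounds shows this exact change, so its effect is unknown. In this assay only a small step is expected, if anything towards a slightly higher number; the expected step is a 1.3-fold higher number from compound 1 to compound 4 (0.12 log units; within the scatter). Compound 4 is estimated to give 320 nM, within a range from 110 nM to 950 nM.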

Compound 4, half-maximal inhibitory concentration: 90 nM
Beside the measured number, compound 4's estimate is 3.6-fold (0.55 log units) above it, and the stated range ends above it.
By their numbers in this assay, from the lowest: compound 4; then compounds 1 and 3 (each within the scatter of the next); then compound 2.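

Replacing the methyl on the amide-type nitrogen with hydrogen brings a 2.7-fold lower number from compound 1 to compound 4 (0.43 log units; beyond the scatter) in this assay and so stronger inhibition. Going by these compounds alone, this single pair gives the first direct reading of this position and shows that the methyl is not needed for inhibition on the core of compound 1. No measurement shown here accounts for the step.

From the compounds shown here alone, whether an ethyl group or a longer chain ending in an amine on this nitrogen would lower or raise the number stays open. Going by these compounds, the step also rests on one pair, so its size on other cores remains unknown.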